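Phenyl for Cyclopropyl: What Compound 3 Might Dissolve To

The source may report more compounds than this note shows. Statements on the series, on what has been measured and on what is new or still open speak of the compounds shown alone.

Of the compounds shown here, two have so far been measured in a physicochemical assay for solubility, read by HPLC, with a stated time of 30 min; on this read-out higher numbers stand for higher solubility and lower numbers for lower solubility. Compound 1 `CC(C)Oc1cccc(-c2csc(NC(=O)c3ccc([N+](=O)[O-])o3)n2)c1` gives 0.27 ug/mL. Compound 2 `O=C(Nc1nc(-c2cccc(NC(=O)C3CC3)c2)cs1)c1ccc([N+](=O)[O-])o1` gives 0.47 ug/mL. Among the measured compounds shown here, the single step between them, a 1.7-fold higher number from compound 1 to compound 2 (0.24 log units; within the scatter), exchanges isopropoxy for (cyclopropylcarbonyl)amino on an aromatic carbon. On the two numbers shown, compound 2 stands at the top, with compound 1 as its nearest neighbour, though the gap between them is within the scatter.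

Compound 3 `O=C(Nc1cccc(-c2csc(NC(=O)c3ccc([N+](=O)[O-])o3)n2)c1)c1ccccc1` differs from compound 2 by phenyl in place of cyclopropyl on a carbonyl carbon; cut one bond further out, cyclopropylcarbonyl becomes benzoyl and (cyclopropylcarbonyl)amino becomes benzamido. For the measured compounds named here, no measured step exchanges these two groups. Going by the values given here, the only step available, a 1.7-fold higher number from compound 1 to compound 2 (0.24 log units; within the scatter), concerns another position and lies within the scatter, so it sets no direction for this change. Resting on the structures alone, compound 3 is expected to give a somewhat lower number in this assay than compound 2, the estimated step being a 1.9-fold lower number from compound 2 to compound 3 (0.27 log units; within the scatter). Compound 3 is estimated at 0.25 ug/mL, within a range from 0.08 ug/mL to 0.8 ug/mL.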

Compound 3, solubility: 1.27 ug/mL
The estimate for compound 3 lay 5.1-fold (0.71 log units) below the measured number; the measured number lies above the stated range.
By their numbers in this assay, from the lowest: compounds 1 and 2 (each within the scatter of the next); then compound 3.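

In this assay this carbonyl carbon, whose other neighbour is an amide-type nitrogen, proves responsive: phenyl in place of cyclopropyl gives a 2.7-fold higher number from compound 2 to compound 3 (0.43 log units; beyond the scatter), a modest step, and it runs upward with the aromatic ring in place of the three-membered one. The same exchange also changes the reading against the isopropoxy compound, since a 1.7-fold higher number from compound 1 to compound 2 (0.24 log units; within the scatter), whereas benzamido in place of isopropoxy on the aromatic carbon gives a 4.7-fold higher number from compound 1 to compound 3 (0.67 log units; beyond the scatter), so that only the benzamido group separates itself from isopropoxy beyond the scatter. Nothing available bears on why the phenyl compound reads higher.

As far as these compounds go, with a single pair at this carbonyl carbon, it stays open whether the step follows from the aromatic ring or from the larger ring, which a cyclohexyl group on the same carbon could separate. From the compounds shown here alone, it also stays open whether an amine or a carboxylic acid carried on the benzoyl group would move the number further, and whether the step would hold on anything other than the shared core.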